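The source may report more compounds than this note shows. Statements on the series, on what has been measured and on what is new or still open speak of the compounds shown alone.

Working notes on the sulfonyl-triazole series, followed in an ADME assay on microsomes from liver (Homo sapiens) for metabolic stability; on this read-out higher numbers stand for fast clearance and lower numbers for slow clearance.

Three compounds carry numbers in this assay. Compound 1 `COc1cc(-c2nnc(S(=O)(=O)C3CCC3)[nH]2)ccc1-c1cnc(OCC(C)C)c(Cl)c1` gives 59 uL/min. Compound 3 `CC(C)COc1ncc(-c2cc(F)c(-c3nnc(S(=O)(=O)NC4CC4)[nH]3)cc2F)cc1Cl` gives 125 uL/min. Compound 2 `O=S(=O)(CC1CC1)c1nnc(-c2cc(F)c(-c3cnc(Oc4ccc(F)cc4F)c(Cl)c3)cc2F)[nH]1` is reported only as a limit of the assay, < 14 uL/min, so it stands at the limit of < 14 uL/min in this assay, at which 1 of the 3 values shown sits, and no number is known for it. On the values shown, compound 2 therefore sits at the slow end of the three, with compound 1 and compound 3 giving numbers above it.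

Compound 4 `O=S(=O)(CC1CC1)c1nnc(-c2cc(F)c(-c3cnc(Oc4ccc(F)cc4Cl)c(Cl)c3)cc2F)[nH]1` differs from compound 2 by chloro in place of fluoro on an aromatic carbon. Among the measured compounds shown here, no measured pair in the set differs in this single place, so the size of the step has no precedent here. For a change of one heavy atom with no ring, donor or acceptor counted, the expectation is a step in this assay no larger than the usual scatter, if anything toward faster clearance; the expected step of an at least 1.1-fold higher number from compound 2 to compound 4 (0.05 log units; that floor lies within the scatter) is small. Compound 4 is expected to give about 16 uL/min, estimated between 7 uL/min and 35 uL/min, with a fair chance that the assay again reports only a limit.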

Compound 4, intrinsic clearance in a liver preparation (reported as CLH), per the amount of preparation that the assay uses: < 14 uL/min
Compound 4: a limit, no number; the forecaster's own chance of this, stated with the estimate: 45%; at least 1.1-fold (0.05 log units) between middle value and limit.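

In this assay compound 2 and compound 4 both stand at a limit of the assay, not at a number, so no step between them can be read: the limit of < 14 uL/min in this assay, at which 2 of the 4 values shown sit.

The compounds shown leave open whether chloro in place of fluoro at this place changes clearance at all.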